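Methoxypiperidine Urea in Place of a Difluorocyclohexyl Ketone

The source may hold more compounds than are shown below. What is called first, only, known or untested is meant among the compounds shown, and "the series" means these compounds.

Three measured compounds share one core and differ only in the group on the carbonyl carbon. Compound 1 `O=C(N1CCC(F)CC1)N1CC(c2nc(-c3cccc(Cl)c3)no2)C1` in an assay on HEK293 cells for negative allosteric modulation of metabotropic glutamate receptor 5 (Homo sapiens), read by FLIPR (a lower number here means a stronger inhibitor, a higher number a weaker inhibitor), gives only a limit, > 10000 nM. Compound 3 `O=C(C1CCC(F)(F)CC1)N1CC(c2nc(-c3cccc(Cl)c3)no2)C1` likewise reaches only the limit of this assay, > 10000 nM. Compound 2 `O=C(C1CCCO1)N1CC(c2nc(-c3cccc(Cl)c3)no2)C1` gives a real number, 890 nM, so that an at least 11-fold higher number from compound 2 to compound 3 (1.05 log units; beyond the scatter), whereas a step that the two limits leave unreadable from compound 1 to compound 3. Compound 3 thus stands at the weak end of what can be read, a position shared by the limit of > 10000 nM in this assay, at which 2 of the 3 values shown sit. Compound 4 `COC1CCCN(C(=O)N2CC(c3nc(-c4cccc(Cl)c4)no3)C2)C1` alters compound 3 by 3-methoxypiperidin-1-yl in place of 4,4-difluorocyclohexyl on a carbonyl carbon. Like compound 1, compound 4 carries a piperidin-1-yl ring on the carbonyl carbon, and compound 1 sits at the limit, while only compound 2 gives a readable number. Compound 4 is therefore expected to remain weak, an at least 1.1-fold lower number from compound 3 to compound 4 (0.04 log units; that floor lies within the scatter), with an estimated value of 9000 nM spanning 2500 nM to 30000 nM.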

Compound 4, half-maximal inhibitory concentration: 1830 nM
Compound 4: middle estimate off by 4.9-fold (0.69 log units), on the high side, outside the stated range (below it).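

Piperidin-1-yl on the carbonyl carbon does not by itself leave a compound weak: 3-methoxypiperidin-1-yl in place of 4-fluoropiperidin-1-yl gives an at least 5.4-fold lower number from compound 1 to compound 4 (0.73 log units; beyond the scatter). Replacing 4,4-difluorocyclohexyl with the same ring gives an at least 5.4-fold lower number from compound 3 to compound 4 (0.73 log units; beyond the scatter). Oxolan-2-yl stays ahead, with a 2.1-fold higher number from compound 2 to compound 4 (0.31 log units; beyond the scatter), and both compounds with readable numbers carry an oxygen in this group. Whether that oxygen itself accounts for the difference stays open, and so does what a hydroxyl or an amine in place of the methoxy would give.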